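A few compounds are considered here, and "the series" means these few. Any claim that something is new, unique, unknown or untested is made for them only; others in the source may bear on it.

Working notes on the series. In an ADME assay on microsomes from liver (Mus musculus) for metabolic stability, with a stated time of 10 min (a lower number here means that less of the compound is left, a higher number that more of the compound is left), compound 2 `CC(=O)N1CC[C@@H](C(=O)N2CC[C@](c3ccc(C(OCc4c(F)cccc4F)(C(F)(F)F)C(F)(F)F)cc3)(S(=O)(=O)c3ccc(F)cc3)C2)C1` gives 55%. Compound 1 `CC(=O)N1CC[C@H](C(=O)N2CC[C@](c3ccc(C(OCc4c(F)cccc4F)(C(F)(F)F)C(F)(F)F)cc3)(S(=O)(=O)c3ccc(F)cc3)C2)C1` gives 57% in this assay, and compound 3 `CC(=O)N1CCC(O)(C(=O)N2CC[C@](c3ccc(C(OCc4c(F)cccc4F)(C(F)(F)F)C(F)(F)F)cc3)(S(=O)(=O)c3ccc(F)cc3)C2)CC1` gives 69%. Compound 2 thus sits at the low end of the three values: the step of a number 2 percentage points lower from compound 1 to compound 2 (within the scatter) stays within the scatter, given (the fact that compounds 1 and 2 differ only in the configuration as drawn), while the steps of a number 14 percentage points higher from compound 2 to compound 3 (beyond the scatter) and a number 12 percentage points higher from compound 1 to compound 3 (beyond the scatter) are both modest rises. Compound 4 `O=C(C1CCOCC1)N1CC[C@](c2ccc(C(OCc3c(F)cccc3F)(C(F)(F)F)C(F)(F)F)cc2)(S(=O)(=O)c2ccc(F)cc2)C1` is not yet measured in this assay; its change from compound 2 is oxan-4-yl in place of 1-acetylpyrrolidin-3-yl on a carbonyl carbon. Among the measured compounds shown here, only the step to compound 3 touches the same carbonyl carbon, and the group entering there was a different one. A small rise or none beyond the scatter is therefore expected for compound 4, a number 7 percentage points higher from compound 2 to compound 4 (within the scatter). Compound 4 is estimated at 62%, in the range 45% to 80%.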

Compound 4, percent of the compound remaining: 29%
Compound 4: middle estimate off by 33 percentage points, on the high side; measured number outside the range, below it.
By their numbers in this assay, from the lowest: compound 4; then compounds 2 and 1 (each within the scatter of the next); then compound 3.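

In this assay the group on this carbonyl carbon can lower the number as well as raise it, with a number 26 percentage points lower from compound 2 to compound 4 (beyond the scatter) and a number 28 percentage points lower from compound 1 to compound 4 (beyond the scatter) for oxan-4-yl in place of 1-acetylpyrrolidin-3-yl. Against 1-acetyl-4-hydroxypiperidin-4-yl, oxan-4-yl gives a number 40 percentage points lower from compound 3 to compound 4 (beyond the scatter) and so this one position spans a large range. Nothing measured in the series accounts for the fall. Still open, on these data alone, is how a cyclohexyl group, a 4-hydroxyoxan-4-yl group or a 1-acetylpiperidin-4-yl group without the hydroxyl would read on the same carbonyl carbon.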